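The source may report more compounds than this note shows. Statements on the series, on what has been measured and on what is new or still open speak of the compounds shown alone.

Working notes on the series. Three compounds share one core and have been run in an ADME assay on HepG2 2.2.15 cells (Homo sapiens) for cytotoxicity; on this read-out higher numbers stand for weaker inhibition and lower numbers for stronger inhibition. Compound 1, `O=C1CCCC2=C1C(c1ccccc1)N=C(c1ccccn1)N2`, gives 571000 nM. Compound 2, `O=C1CCCC2=C1C(c1ccc(F)cc1)N=C(c1ccccn1)N2`, gives 516000 nM. Compound 3, `O=C1CCCC2=C1C(c1ccc(F)cc1Cl)N=C(c1cnccn1)N2`, gives 777000 nM; it stands highest of the three numbers, yet its gaps to compound 1 and to compound 2 both lie within the scatter, so no order among the three is claimed.

One change has a measured precedent. Between compound 2 and compound 1 the difference is hydrogen in place of fluoro on an aromatic carbon, and in this assay it made a 1.1-fold higher number from compound 2 to compound 1 (0.04 log units; within the scatter). Compound 4, `O=C1CCCC2=C1C(c1ccccc1Cl)N=C(c1cnccn1)N2`, is not yet measured; it differs from compound 3 by hydrogen in place of fluoro on an aromatic carbon. This is the same kind of change as that from compound 2 to compound 1, not the same: in compound 3 the carbon concerned is meta to a chloro group (1 heavy atom) as well as para to a large group, whereas in compound 2 it is only para to a large group. The difference between the cores of compound 2 and compound 3 is not broken down here.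

Because the step of a 1.1-fold higher number from compound 2 to compound 1 (0.04 log units; within the scatter) stayed within the scatter, the step from compound 3 to compound 4 in this assay is expected to be small as well, a 1.0-fold higher number from compound 3 to compound 4 (0.01 log units; within the scatter). On this basis compound 4 is estimated at 800000 nM, with a range from 400000 nM to 1600000 nM.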

Compound 4, half-maximal inhibitory concentration: 1470000 nM
Estimate against measurement, compound 4: 1.8-fold (0.26 log units) below, within the range that was stated.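

In this assay, the new step reads a 1.9-fold higher number from compound 3 to compound 4 (0.28 log units; within the scatter), the change being 2-chloro-4-fluorophenyl to 2-chlorophenyl. Set beside the earlier case, the two steps do not differ by more than repeated measurement allows: the same change on two cores in this assay, a 1.1-fold higher number (0.04 log units; within the scatter) from compound 2 to compound 1 and a 1.9-fold higher number (0.28 log units; within the scatter) from compound 3 to compound 4, 1.7-fold (0.23 log units) apart, within the scatter of two such steps. Among these compounds, on these two cores, then, hydrogen in place of fluoro on this aromatic carbon gives no step that can be told from scatter and no sign that the core alters the outcome, but this does not show that the change carries over in general: there are only two pairs, the carbon is meta to a chloro group in only one of them, and a modest dependence on the core cannot be excluded.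

The compounds shown leave open how this read-out responds to groups other than fluoro or hydrogen on this carbon, such as a methoxy group, an amine or a carboxylic acid. They also leave open what the chloro group and the remaining difference between compound 2 and compound 3 each contribute on their own, as no pair shown differs in only one of those places.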